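Bromo for hydroxy on the aminoanilide cap

A few compounds are considered here, and "the series" means these few. Any claim that something is new, unique, unknown or untested is made for them only; others in the source may bear on it.

Measured so far in an assay for inhibition of histone deacetylase 8 (Homo sapiens), read by fluorescence, with stated times of 15 min and 60 min; a higher number here means a weaker inhibitor, a lower number a stronger inhibitor:
compound 1 `Nc1cc(O)ccc1NC(=O)c1ccc(CNc2nccc(-c3cccnc3)n2)cc1`: > 20000 nM
compound 2 `CC(=O)N1C(NCc2ccc(C(=O)Nc3ccccc3N)cc2)=NC(=O)C1Cc1c[nH]c2ccccc12`: 24300 nM

In this assay compound 1 gives > 20000 nM, which is a limit of the assay and not a number. Compound 2 in this assay gives 24300 nM. Within the data shown here, compound 1 thus stands at the limit of > 20000 nM in this assay, at which 1 of the 2 values shown sits; its true value is unknown beyond that, and no measured step links it to compound 2.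

Compound 3 `Nc1cc(Br)ccc1NC(=O)c1ccc(CNc2nccc(-c3cccnc3)n2)cc1` is not yet measured. It differs from compound 1 by bromo in place of hydroxy on an aromatic carbon. Among the measured compounds shown here, no pair of measured compounds that differ in one place is available to calibrate this change, so the expectation rests on the limit alone. The step from compound 1 to compound 3 in this assay is expected to be an at least 2.0-fold lower number from compound 1 to compound 3 (0.30 log units; that floor lies within the scatter), toward stronger inhibition, though a second limit cannot be excluded. For compound 3 the expected value in this assay is 10000 nM, within 2000 nM to 40000 nM.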

Compound 3, half-maximal inhibitory concentration: > 20000 nM
Compound 3: no number, only a limit; the forecaster's own chance of this, stated with the estimate: 40%; middle value at least 2.0-fold (0.30 log units) away from the limit.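

In this assay compound 3 gives > 20000 nM, a limit of the assay and not a number. Compound 1 also stands at a limit, so no step between compound 1 and compound 3 can be read: the limit of > 20000 nM in this assay, at which 2 of the 3 values shown sit.

The compounds shown leave open whether bromo and hydroxy differ at all in this inhibition, and how far either compound's true value lies beyond the limit.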